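A few compounds are considered here, and "the series" means these few. Any claim that something is new, unique, unknown or untested is made for them only; others in the source may bear on it.

Compound 1 `Cc1ccc2nc(N(C)C)nc(NCc3ccc(C(=O)NCc4ccc(F)cc4)cc3)c2c1`: 900 nM
Compound 2 `Cc1ccc2nc(N(C)C)nc(NCc3ccc(C(=O)N[C@H]4C[C@@H]4c4ccccc4)cc3)c2c1`: 1300 nM
Compound 3 `Cc1ccc2nc(N(C)C)nc(NCc3ccc(C(=O)Nc4ccc(Cl)nc4)cc3)c2c1`: 1300 nM

In a functional assay on HCT-116 cells (Homo sapiens) for inhibition, read by luminescence and resazurin assay, with a stated time of 3 days (on this read-out lower numbers stand for stronger inhibition and higher numbers for weaker inhibition), compound 2 gives 1300 nM, level with compound 3 and together with it the highest of the three numbers; the step of a 1.4-fold higher number from compound 1 to compound 2 (0.16 log units; within the scatter) and the step of no change at the digits printed from compound 2 to compound 3 (within the scatter) both lie within the scatter. Compound 4 `CCNc1nc(NCc2ccc(C(=O)N[C@H]3C[C@@H]3c3ccccc3)cc2)c2cc(C)ccc2n1` differs from compound 2 in one place: ethylamino in place of dimethylamino on an aromatic carbon. Among the compounds with values here, none of the measured steps touches this position; all three exchange the group on the amide-type nitrogen and all stay within the scatter, so no measured step bears directly on this change. With no guidance from the data, the expectation is no step beyond the scatter, no change at the digits printed from compound 2 to compound 4 (within the scatter). Compound 4 is therefore estimated at 1300 nM, with a range from 500 nM to 3500 nM.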

Compound 4, half-maximal inhibitory concentration: 1700 nM
Compound 4: the middle estimate sits 1.3-fold (0.12 log units) below what was measured; measured number inside the range.
By their numbers in this assay, from the lowest: compounds 1, 2, 3 and 4 (each within the scatter of the next).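

In this assay, ethylamino in place of dimethylamino gives a 1.3-fold higher number from compound 2 to compound 4 (0.12 log units; within the scatter). Within the data shown here, this is the first measured change at this position, between two ring nitrogen atoms, and it shows that bringing in a hydrogen-bond donor, where dimethylamino has none, leaves the number within the scatter. Nothing available explains this result. Still open, from the compounds shown here alone, is how a plain amino group, a longer chain such as butylamino, or a ring such as morpholine would read here. Going by these compounds, whether ethylamino behaves the same alongside the amide groups of compound 1 and compound 3 is also open.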